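Replacing the 3,5-Dibromo-4-Hydroxyphenyl Group of Compound 3

This account rests on a few compounds, and the source may have more. Where it says the series, first, only, none or still open, it means among the compounds named here.

In a functional assay on HepG2 cells (Homo sapiens) for cytotoxicity, read by MTT assay, with a stated time of 72 h (on this read-out higher numbers stand for weaker inhibition and lower numbers for stronger inhibition), compound 1 (`N#Cc1ccc(/C=N/NC(=O)Nc2cc3c(Nc4ccc(F)c(Cl)c4)ncnc3cc2O[C@H]2CCOC2)cc1`) gives 26400 nM and compound 2 (`O=C(N/N=C/c1ccc([N+](=O)[O-])cc1)Nc1cc2c(Nc3ccc(F)c(Cl)c3)ncnc2cc1O[C@H]1CCOC1`) gives 35300 nM as its result. These two values stand level (a 1.3-fold higher number from compound 1 to compound 2 (0.13 log units; within the scatter)). Compound 3 (`O=C(N/N=C/c1cc(Br)c(O)c(Br)c1)Nc1cc2c(Nc3ccc(F)c(Cl)c3)ncnc2cc1O[C@H]1CCOC1`) gives 2740 nM and holds the lowest of the three numbers, with both of its steps beyond the scatter (a 9.6-fold lower number from compound 1 to compound 3 (0.98 log units; beyond the scatter)) and (a 13-fold lower number from compound 2 to compound 3 (1.11 log units; beyond the scatter)).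

Compound 4 (`CCN(CC)c1ccc(/C=N/NC(=O)Nc2cc3c(Nc4ccc(F)c(Cl)c4)ncnc3cc2O[C@H]2CCOC2)c(O)c1`) has not yet been measured. It carries 4-(diethylamino)-2-hydroxyphenyl in place of 3,5-dibromo-4-hydroxyphenyl on a carbon with a double bond to nitrogen. Going by the values given here, no measured compound carries the entering group, so the evidence is indirect. The two steps into compound 3 show only what exchanging the leaving group for 4-cyanophenyl or 4-nitrophenyl did. The entering group matches neither of these, so only part of those steps is expected to return in this assay and the number is expected to rise. The expected move is a 3.6-fold higher number from compound 3 to compound 4 (0.56 log units; beyond the scatter) and is smaller than either step into compound 3. Compound 4 is estimated at 10000 nM with an expected range from 2500 nM to 40000 nM for this measurement.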

Compound 4, half-maximal inhibitory concentration: 15700 nM
The estimate for compound 4 lay 1.6-fold (0.20 log units) below the measured number; low and high end bracket the measured number.
By their numbers in this assay, from the lowest: compound 3; then compounds 4, 1 and 2 (each within the scatter of the next, the first and the last beyond it).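

In this assay, the exchange of 3,5-dibromo-4-hydroxyphenyl for 4-(diethylamino)-2-hydroxyphenyl on the carbon with a double bond to nitrogen gives a 5.7-fold higher number from compound 3 to compound 4 (0.76 log units; beyond the scatter). Both groups carry a hydroxy group on the phenyl ring, so among these compounds a hydroxy group alone does not go with the low number of compound 3. Against the earlier groups, the entering group gives a 2.2-fold lower number from compound 2 to compound 4 (0.35 log units; beyond the scatter) and a 1.7-fold lower number from compound 1 to compound 4 (0.23 log units; within the scatter), which separates compound 4 from compound 2 but not from compound 1, and nothing measured here speaks to the reason for these differences.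

As far as these compounds go, what a plain 4-hydroxyphenyl group or a 3,5-dibromophenyl group would give at this position stays open, so the low number of compound 3 cannot yet be assigned to the two bromine atoms, to the hydroxy group or to the two together. Also open, from the compounds shown here alone, is whether the diethylamino group or the hydroxy group drives the number of compound 4, a question that a 4-(diethylamino)phenyl group would address.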